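The compounds below may be only part of what the source reports. "The series", "measured", "known", "first", "only" and "open" are said of these compounds alone.

Compound 1 `CCN(CC)c1cc2[nH]c(C3CCCCC3)nc2cc1NC(=O)OCC(F)(F)F` sits at the upper limit of the measured set. In an ADME assay on Vero cells (Chlorocebus sabaeus) for cytotoxicity, read by resazurin assay, with a stated time of 3 days (a lower number here means a stronger inhibitor, a higher number a weaker inhibitor), compound 1 gives > 100 ug/mL, which is a limit of the assay and not a number. Compound 2 `CN(C)c1cc2[nH]c(C3CCCCC3)nc2cc1NC(=O)OCC(F)(F)F` is its nearest neighbour. In this assay compound 2 gives > 100 ug/mL, also a limit. Compound 3 `CN(C)c1cc2[nH]c(C3CCCCC3)nc2cc1NC(=O)c1ccc(OC(F)F)cc1` completes the measured group. In this assay compound 3 gives > 100 ug/mL, once more a limit. The step from compound 1 to compound 2 reads a step that the two limits leave unreadable from compound 1 to compound 2, and the step from compound 2 to compound 3 reads a step that the two limits leave unreadable from compound 2 to compound 3; neither can be sized, since both ends are limits. What remains is the limit of > 100 ug/mL in this assay, at which 3 of the 3 values shown sit, and that is the whole of the evidence.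

Compound 4 `CCCOCC(=O)Nc1cc2nc(C3CCCCC3)[nH]c2cc1N(CC)CC` has not yet been measured. It differs from compound 1 in one place: propoxymethyl in place of 2,2,2-trifluoroethoxy on a carbonyl carbon. For the measured compounds named here, the only measured step that also touches the group on the carbonyl carbon is a step that the two limits leave unreadable from compound 2 to compound 3, and it left compound 3 at the limit. Compound 4 is therefore expected to remain at the limit as well. The expected step is a step that the limit leaves unreadable from compound 1 to compound 4, nothing beyond the scatter. Compound 4 is estimated at 150 ug/mL, in a range from 60 ug/mL to 400 ug/mL.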

Compound 4, half-maximal inhibitory concentration: > 100 ug/mL
Compound 4 ended at the assay's limit (the forecaster's own chance of this, stated with the estimate: 85%); the middle value is on the limit's open side.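

For the compounds shown here, compound 1 and compound 4 both stand at a limit of this assay, so the step between them cannot be read, and this result adds no new step. The compounds shown leave open how far each lies past that limit and whether any change would give a readable value, since the evidence rests on one point: the limit of > 100 ug/mL in this assay, at which 4 of the 4 values shown sit.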